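The source may report more compounds than this note shows. Statements on the series, on what has been measured and on what is new or still open speak of the compounds shown alone.

Measured compounds in a functional assay on NCI-H1975 cells (Homo sapiens) for antiproliferative activity, read by MTT assay, with a stated time of 72 h; a lower number here means a stronger inhibitor, a higher number a weaker inhibitor:

compound 1 `CN1CCN(c2ccc(Nc3ncc4nc(Nc5ccc(F)cc5)n([C@H]5CCCN(S(=O)(=O)C6CC6)C5)c4n3)cc2)CC1` gives 1150 nM
compound 2 `CN1CCN(c2ccc(Nc3ncc4nc(Nc5ccccc5)n([C@H]5CCNC5)c4n3)cc2)CC1` gives "not determined" (no result reported)
compound 3 `CN1CCN(c2ccc(Nc3ncc4nc(Nc5ccccc5)n([C@@H]5CCNC5)c4n3)cc2)CC1` gives "not determined" (no result reported)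

Compound 3 stands on no number at all: in this assay compound 3 returned "not determined" (no result reported), and compound 2 likewise returned "not determined" (no result reported), so neither the compound itself nor its mirror partner anchors the series. The only point worth noting about that pair is the fact that compounds 2 and 3 differ only in the configuration as drawn, which gives no potency information. Among the measured compounds shown here, the one figure in hand comes from compound 1, which in this assay gives 1150 nM; it shares the cyclopropylsulfonyl group with compound 4 but differs in other places, and no step between them is computed.

Compound 4 `CN1CCN(c2ccc(Nc3ncc4nc(Nc5ccccc5)n([C@@H]5CCN(S(=O)(=O)C6CC6)C5)c4n3)cc2)CC1` arises from compound 3 by cyclopropylsulfonyl in place of hydrogen on an amine nitrogen in a ring, read one bond further out as pyrrolidin-3-yl becoming 1-(cyclopropylsulfonyl)pyrrolidin-3-yl. With no measured step of this kind in the set, no direction can be derived; a change within the usual scatter of this assay is the default expectation, with the value of compound 1 as the nearest reference point.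

On that basis compound 4 is estimated in this assay at 1000 nM, with a range from 250 nM to 4000 nM.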

Compound 4, half-maximal inhibitory concentration: 200 nM
For compound 4 the middle estimate is 5.0-fold (0.70 log units) above the measured one; the whole stated range lies above it.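

In this assay compound 4 gives 200 nM while compound 3 carries no single number, so no step can be read from compound 3 to compound 4. Open remains what cyclopropylsulfonyl in place of hydrogen on the amine nitrogen does to the value, and whether the configuration as drawn matters. Nothing on hand accounts for the value of compound 4.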